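This account rests on a few compounds, and the source may have more. Where it says the series, first, only, none or still open, it means among the compounds named here.

Compound 1: `CC(C(=O)NCc1ccc(C(F)(F)F)nc1-c1ccccc1)c1ccc(NS(C)(=O)=O)c(F)c1` — 6.4 nM
Compound 2: `CC(C(=O)NCc1ccc(C(F)(F)F)nc1-c1ccc(F)c(Cl)c1)c1ccc(NS(C)(=O)=O)c(F)c1` — 0.2 nM
Compound 3: `CC(C(=O)NCc1ccc(C(F)(F)F)nc1-c1ccc(Cl)c(Cl)c1)c1ccc(NS(C)(=O)=O)c(F)c1` — 0.9 nM

All three share one core and differ only in the aromatic ring attached to it. In an assay on CHO cells for antagonist activity at transient receptor potential cation channel subfamily V member 1 (Homo sapiens), read by FLIPR (a higher number here means a weaker inhibitor, a lower number a stronger inhibitor), compound 3 gives the second highest of the three numbers: a 4.5-fold higher number from compound 2 to compound 3 (0.65 log units; beyond the scatter), and a 7.1-fold lower number from compound 1 to compound 3 (0.85 log units; beyond the scatter). Compound 4 is `CC(C(=O)NCc1ccc(C(F)(F)F)nc1-c1ccc2cc[nH]c2c1)c1ccc(NS(C)(=O)=O)c(F)c1`. The change from compound 3 is 1H-indol-6-yl in place of 3,4-dichlorophenyl on an aromatic carbon.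

The measured steps all concern substituents on that same ring: a 32-fold lower number from compound 1 to compound 2 (1.51 log units; beyond the scatter), a 7.1-fold lower number from compound 1 to compound 3 (0.85 log units; beyond the scatter) and a 4.5-fold higher number from compound 2 to compound 3 (0.65 log units; beyond the scatter). They show that what sits on this ring shifts the number substantially, in either direction. None of them, however, exchanges a single six-membered ring for a two-ring system or introduces a hydrogen-bond donor, so they set the scale of what this position can do without fixing the direction for compound 4. A modest move is therefore expected, more likely toward a higher number than a lower one, since the two chlorines that helped compound 3 are gone. The expected step is a 3.3-fold higher number from compound 3 to compound 4 (0.52 log units; beyond the scatter). Compound 4 is estimated to give 3 nM in this assay, with a range from 0.5 nM to 20 nM.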

Compound 4, inhibition constant: 20.3 nM
For compound 4 the middle estimate is 6.8-fold (0.83 log units) below the measured one; measured number outside the range, above it.
By their numbers in this assay, from the lowest: compound 2; then compound 3; then compound 1; then compound 4.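

In this assay the 1H-indol-6-yl group costs far more than the halogens on the earlier rings were worth: the change is a 23-fold higher number from compound 3 to compound 4 (1.35 log units; beyond the scatter) against the 3,4-dichlorophenyl ring and a 100-fold higher number from compound 2 to compound 4 (2.01 log units; beyond the scatter) against the 3-chloro-4-fluorophenyl ring. It also ends up on the far side of the plain phenyl ring, with a 3.2-fold higher number from compound 1 to compound 4 (0.50 log units; beyond the scatter) for this swap, so this place on the core, where both earlier changes had lowered the number relative to phenyl, can raise it as well. The change brings in a second aromatic ring and a hydrogen-bond donor at once, and no measurement at hand explains which of these, if either, lies behind the rise.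

The compounds shown leave those two features unseparated: a naphthyl group would keep two aromatic rings without the donor, while a 1-methylindol-6-yl group would keep the indole with a methyl on its ring nitrogen. Also open, as far as these compounds go, are whether the attachment point matters, as a 1H-indol-5-yl group would show, and whether an amine on the phenyl ring would bring in a donor without the second ring.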